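Dropping a cyclopropyl from a benzothiazole acylurea

The source may report more compounds than this note shows. Statements on the series, on what has been measured and on what is new or still open speak of the compounds shown alone.

Measured compounds:
compound 1, `CN1CCN(CCCS(=O)(=O)c2ccc3nc(NC(=O)NC(=O)c4cc(C5CC5)ccc4Cl)sc3c2)CC1`, 2.9
compound 2, `CS(=O)(=O)c1ccc2sc(NC(=O)NC(=O)c3ccccc3Cl)nc2c1`, 2.8
compound 3, `CN1CCN(CCCS(=O)(=O)c2ccc3nc(NC(=O)NC(=O)c4cc(-n5cccn5)c(Cl)cc4Cl)sc3c2)CC1`, 2.3

Of the compounds shown here, three have been measured in a physicochemical assay for lipophilicity; on this read-out higher numbers stand for higher lipophilicity and lower numbers for lower lipophilicity. Compound 1 gives 2.9, the highest of the three numbers shown, though compound 2, at 2.8, sits within the usual scatter of it, so the two cannot be told apart. Compound 3, at 2.3, lies clearly lower, beyond the scatter.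

The new compound is compound 4, `CN1CCN(CCCS(=O)(=O)c2ccc3nc(NC(=O)NC(=O)c4ccccc4Cl)sc3c2)CC1`. It differs from compound 1 in one place: hydrogen in place of cyclopropyl on an aromatic carbon. Among the compounds with values here, none of the measured pairs differs in exactly this way, so no measured step is available to lean on, and the expectation rests on the change alone: a group of three carbon atoms leaves and a single hydrogen atom enters.

For this change a downward step in this assay is expected, clearly beyond the scatter, estimated at a number 0.90 log units lower from compound 1 to compound 4 (beyond the scatter). Compound 4 is therefore expected to give about 2, with a likely range from 1.5 to 2.6.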

Compound 4, distribution coefficient: 1.8
Beside the measured number, compound 4's estimate is 0.20 log units above it; low and high end bracket the measured number.
By their numbers in this assay, from the lowest: compound 4; then compound 3; then compounds 2 and 1 (each within the scatter of the next).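

With hydrogen in place of cyclopropyl on this aromatic carbon, para to a chloro group, this assay gives a number 1.10 log units lower from compound 1 to compound 4 (beyond the scatter), and the step is large. The earlier compounds shown here offered no pair differing in one place, so they could not show how much this position matters; this pair isolates it, and the cyclopropyl-to-hydrogen change alone moves the number well beyond the scatter. Nothing available explains why the step has this size.

The compounds shown leave open how the number would respond to other groups on this carbon, such as methyl, methoxy or an amine. Within the data shown here, they also leave open whether the same change would give a similar step on a different chain, such as the one carried by compound 2.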